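From propargylamino to ethoxy on compound 2

The source may hold more compounds than are shown below. What is called first, only, known or untested is meant among the compounds shown, and "the series" means these compounds.

Compound 1 (`CC#Cc1nc(C(=O)OCC)cs1`): > 40000 nM
Compound 2 (`C#CCNC(=O)c1csc(C#Cc2ccccc2)n1`): > 40000 nM
Compound 3 (`C#CCNC(=O)c1csc(C#C)n1`): 19200 nM

All three compounds were tested in a functional assay on HCT-116 cells (Homo sapiens) for cytotoxicity, with a stated time of 3 days; on this read-out higher numbers stand for weaker inhibition and lower numbers for stronger inhibition. Compound 2 gives > 40000 nM here, which is a limit and not a number. Compound 1 also reports only a limit, > 40000 nM, so compound 2 stands at the limit of > 40000 nM in this assay, at which 2 of the 3 values shown sit. Compound 3 gives a true number, 19200 nM.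

Among the measured compounds shown here, the one measured step is an at least 2.0-fold lower number from compound 2 to compound 3 (0.31 log units; beyond the scatter). It lies at a different place from the change considered here, so it bears on that change only indirectly.

Compound 4 (`CCOC(=O)c1csc(C#Cc2ccccc2)n1`) has not yet been measured. It differs from compound 2 at one place: ethoxy in place of propargylamino on a carbonyl carbon. For the measured compounds named here, no measured step covers this exchange. Compound 1 also carries ethoxy on a carbonyl carbon, and its > 40000 nM is again only a limit. No step beyond the scatter is therefore expected in this assay, and a reading at the limit is quite likely.

The expected change is a number no higher from compound 2 to compound 4 (the limit leaves the size open). For compound 4 the estimated value is 40000 nM, with an expected range from 15000 nM to 80000 nM.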

Compound 4, half-maximal inhibitory concentration: > 40000 nM
Compound 4 ended at the assay's limit; the forecaster's own chance of this, stated with the estimate: 70%; the middle value sits exactly at the limit.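

In this assay compound 4 gives > 40000 nM, which is a limit of the assay and not a number. Compound 1 and compound 2 also report only limits, so neither step to compound 4 can be read. The compounds shown leave open whether ethoxy in place of propargylamino on a carbonyl carbon changes the reading at all.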